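Shortening the chain: from compound 3 to compound 4

The source may report more compounds than this note shows. Statements on the series, on what has been measured and on what is new or still open speak of the compounds shown alone.

The shared core of this series carries an amide chain ending in a benzene ring. Compound 1 `COc1cccc(CCCC(=O)Nc2nc3ccccc3c(=O)s2)c1` gives 1300 nM in an assay on mitochondria (strain Sprague-Dawley) for inhibition of Amine oxidase [flavin-containing] B (Rattus norvegicus), read by fluorescence and Amplex Red, with stated times of 30 min and 45 min; on this read-out lower numbers stand for stronger inhibition and higher numbers for weaker inhibition. Compound 2 `CN(C(=O)CCCc1ccccc1)c1nc2ccccc2c(=O)s1` has "not determined" (no result reported) in this assay. Going by the values given here, compound 3 `O=C(CCCc1ccccc1)Nc1nc2ccccc2c(=O)s1` gives 186 nM in this assay, the lowest of the two numbers known; the one measured step, a 7.0-fold lower number from compound 1 to compound 3 (0.84 log units; beyond the scatter), concerns the methoxy group and not the chain. Compound 4 `O=C(CCc1ccccc1)Nc1nc2ccccc2c(=O)s1` differs from compound 3 by phenyl in place of benzyl on a saturated chain carbon, two bonds along the chain from a carbonyl carbon. Among the compounds with values here, no measured pair changes the chain length, so nothing here bears directly on this step, and the expected change is none beyond the scatter, with wide uncertainty. Compound 4 is estimated at 250 nM (range 60 nM to 1000 nM), a step of a 1.3-fold higher number from compound 3 to compound 4 (0.13 log units; within the scatter).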

Compound 4, half-maximal inhibitory concentration: 42.7 nM
Estimate against measurement, compound 4: 5.9-fold (0.77 log units) above, outside the stated range (below it).
By their numbers in this assay, from the lowest: compound 4; then compound 3; then compound 1.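

In this assay the chain itself proves to matter, and not only the methoxy group on its ring: phenyl in place of benzyl gives a 4.4-fold lower number from compound 3 to compound 4 (0.64 log units; beyond the scatter) and leaves compound 4 with the lowest number of the three measured compounds. A shorter chain is therefore better tolerated here than the longer one, at least for this single pair. Nothing available explains why this shortening lowers the number.

As far as these compounds go, whether a still shorter chain would lower the number further remains open. So does whether a methoxy group or an amine on the benzene ring of compound 4 would be tolerated.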